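Phenyl for pyridin-2-yl in a cytotoxicity series

This account rests on a few compounds, and the source may have more. Where it says the series, first, only, none or still open, it means among the compounds named here.

Compound 1 `C=C1C[C@]23C[C@@]1(O)CC[C@H]2c1ccc(O)c(C)c1[C@@H]3Cn1cc(-c2ccccn2)nn1` and compound 3 `C=C1C[C@]23C[C@@]1(O)CC[C@H]2c1ccc(O)c(C)c1[C@@H]3Cn1cc(-c2ccccc2)nn1` share one core; compound 2 `C=C1C[C@]23C[C@@]1(O)CC[C@@H]2c1cccc(C)c1[C@@H]3Cn1cc(-c2ccccn2)nn1` and the as yet unmeasured compound 4 `C=C1C[C@]23C[C@@]1(O)CC[C@@H]2c1cccc(C)c1[C@@H]3Cn1cc(-c2ccccc2)nn1` share another, and how the core of compound 2 differs from the core of compound 1 is not broken down here. Within each pair the only change is on the five-membered ring.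

In a functional assay on SMMC-7721 cells (Homo sapiens) for cytotoxicity, read by MTT assay, with a stated time of 4 days (a higher number here means a weaker inhibitor, a lower number a stronger inhibitor), compound 1 gives only a limit of the assay, > 20000 nM. Compound 3 likewise gives only a limit in this assay, namely > 20000 nM. Compound 2 also gives only a limit in this assay, > 20000 nM.

The change from compound 1 to compound 3 is phenyl in place of pyridin-2-yl on an aromatic carbon. The step it made, a step that the two limits leave unreadable from compound 1 to compound 3, stays unreadable due to the limit of > 20000 nM in this assay, at which 3 of the 3 values shown sit. The change from compound 2 to compound 4 is the same change at the same place, (phenyl in place of pyridin-2-yl on an aromatic carbon).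

Since the measured pair gives no readable size for this change, the expectation for compound 4 rests only on the unreadable step from compound 1 to compound 3, a step that the two limits leave unreadable from compound 1 to compound 3, and is worded as a step that the limit leaves unreadable from compound 2 to compound 4 in this assay, that is, no movement that the assay could resolve. Compound 4 is therefore estimated at 30000 nM in this assay, with a plausible span from 15000 nM to 100000 nM, and most probably it will again be reported only as a limit.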

Compound 4, half-maximal inhibitory concentration: > 20000 nM
Compound 4 was reported as a limit; the forecaster's own chance of this, stated with the estimate: 85%; the middle value lies beyond the limit too.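

No size can be read for phenyl in place of pyridin-2-yl, either between compound 2 and compound 4 or between compound 1 and compound 3, due to what all four compounds share: the limit of > 20000 nM in this assay, at which 4 of the 4 values shown sit.

The compounds shown leave open whether this change, or the difference between the two cores, alters the response in this assay at all, since none of them gives a value inside the readable range.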